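Swapping azido for formyl in compound 3

The source may report more compounds than this note shows. Statements on the series, on what has been measured and on what is new or still open speak of the compounds shown alone.

Compound 1 `[N-]=[N+]=Nc1cc(=O)[nH]c(=O)n1[C@@H]1O[C@H](CO)[C@@H](O)[C@H]1O`: > 50000 nM (a limit of the assay)
Compound 2 `O=Cc1cc(=O)[nH]c(=O)n1[C@@H]1O[C@H](CO)[C@@H](O)[C@H]1O`: > 50000 nM (a limit of the assay)
Compound 3 `[N-]=[N+]=Nc1c(F)c(=O)[nH]c(=O)n1[C@@H]1O[C@H](CO)[C@@H](O)[C@H]1O`: 700 nM

Going by the values given here, in a functional assay on OCI-AML2 cells (Homo sapiens) for antiproliferative activity, read by WST assay, with a stated time of 3 days (on this read-out higher numbers stand for weaker inhibition and lower numbers for stronger inhibition), compound 3 gives 700 nM, the only true number in the set. The two other readings both sit at one ceiling, (the limit of > 50000 nM in this assay, at which 2 of the 3 values shown sit), so compound 3 cannot be placed against a second number.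

Compound 4 `O=Cc1c(F)c(=O)[nH]c(=O)n1[C@@H]1O[C@H](CO)[C@@H](O)[C@H]1O` keeps the fluoro group of compound 3 and carries formyl in place of azido on an aromatic carbon.

Among the compounds with values here, two measured steps bear on this change. The same replacement without the fluoro group is a step that the two limits leave unreadable from compound 1 to compound 2, which gives direction but no size. The fluoro step is an at least 71-fold lower number from compound 1 to compound 3 (1.85 log units; beyond the scatter), and it is large and beyond the scatter. If that gain carries over to the formyl series, compound 4 should give a real number, but no measured pair tests this. Nothing yet shows that formyl can match azido, so a moderate loss seems the likelier outcome, with a real chance of reaching the limit.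

The expected change is a 4.3-fold higher number from compound 3 to compound 4 (0.63 log units; beyond the scatter), towards weaker inhibition. For compound 4 the estimated value is 3000 nM, with an expected range of 400 nM to 30000 nM.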

Compound 4, half-maximal inhibitory concentration: 700 nM
Compound 4: the middle estimate sits 4.3-fold (0.63 log units) above what was measured, and the stated range covers the measured number.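

In this assay, formyl can take the place of azido on this aromatic carbon, next to the ring nitrogen and ortho to a fluoro group, with no readable cost, as the step shows: no change at the digits printed from compound 3 to compound 4 (within the scatter). Going by these compounds alone, the fluoro step, until now seen only with azido, also appears with formyl, as an at least 71-fold lower number from compound 2 to compound 4 (1.85 log units; beyond the scatter), so in both pairs the compound carrying the fluoro group gives a true number while its partner without that group does not. Across these two pairs the fluoro change therefore matters far more than the choice between azido and formyl, although the two fluoro steps can be compared only in direction: the same change on two cores in this assay, an at least 71-fold lower number (1.85 log units; beyond the scatter) from compound 1 to compound 3 and an at least 71-fold lower number (1.85 log units; beyond the scatter) from compound 2 to compound 4; the limit leaves it open whether they differ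

On these data alone, the size of the fluoro step remains unknown in either pair, and how azido and formyl compare without the fluoro group cannot be read: the limit of > 50000 nM in this assay, at which 2 of the 4 values shown sit. It also remains open whether an amine or a carboxylic acid on the same aromatic carbon would keep the activity of compound 3 and compound 4, and whether chloro or methyl could replace the fluoro group.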